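From a 4-chlorobenzyl to a 4-methylphenyl amide

The source may hold more compounds than are shown below. What is called first, only, known or untested is meant among the compounds shown, and "the series" means these compounds.

In a functional assay on CHP-134 cells (Homo sapiens) for antiproliferative activity, with a stated time of 72 h (a lower number here means a stronger inhibitor, a higher number a weaker inhibitor), compound 3 `CN(C)c1ccc(C(=O)N(CCC(=O)NCc2ccc(Cl)cc2)Cc2ccc(C(=O)NO)cc2)cc1` gives 610 nM, within the scatter of both compound 1 `Cc1ccc(CNC(=O)CCN(Cc2ccc(C(=O)NO)cc2)C(=O)c2ccc(N(C)C)cc2)cc1` at 420 nM and compound 2 `Cc1ccc(NC(=O)CCN(Cc2ccc(C(=O)NO)cc2)C(=O)c2ccccc2)cc1` at 1160 nM. Compound 4 `Cc1ccc(NC(=O)CCN(Cc2ccc(C(=O)NO)cc2)C(=O)c2ccc(N(C)C)cc2)cc1` has not yet been measured. The change from compound 3 is 4-methylphenyl in place of 4-chlorobenzyl on an amide-type nitrogen, with 4-methylphenyl in place of 4-chlorobenzyl on an amide-type nitrogen.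

Going by the values given here, one measured step bears on the chloro and methyl part of this exchange: a 1.5-fold higher number from compound 1 to compound 3 (0.16 log units; within the scatter). Among the compounds with values here, no measured step isolates the change from benzyl to phenyl. Compound 2 carries the same 4-methylphenyl group and gives 1160 nM, but it also differs from compound 4 elsewhere, so it offers only a loose guide. On this evidence, no change beyond the scatter is expected in this assay, although a slightly higher number would fit compound 2. The expected change is a 1.2-fold higher number from compound 3 to compound 4 (0.09 log units; within the scatter). For compound 4 the estimated value is 750 nM, with an expected range of 320 nM to 1700 nM.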

Compound 4, half-maximal inhibitory concentration: 540 nM
For compound 4 the middle estimate is 1.4-fold (0.14 log units) above the measured one; the measured number falls inside the stated range.
By their numbers in this assay, from the lowest: compounds 1, 4, 3 and 2 (each within the scatter of the next, the first and the last beyond it).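

In this assay, the full exchange of 4-chlorobenzyl for 4-methylphenyl on the amide-type nitrogen stays within the scatter (a 1.1-fold lower number from compound 3 to compound 4 (0.05 log units; within the scatter)). Going by these compounds alone, the new compound also gives the first reading of 4-methylphenyl in place of 4-methylbenzyl with the chloro group out of play, and this too stays within the scatter (a 1.3-fold higher number from compound 1 to compound 4 (0.11 log units; within the scatter)). Within the data shown here, it further isolates dimethylamino in place of hydrogen on an aromatic carbon, the only new step beyond the scatter, though modest (a 2.1-fold lower number from compound 2 to compound 4 (0.33 log units; beyond the scatter)).

Nothing measured here explains these steps. From the compounds shown here alone, whether the dimethylamino step holds with the 4-methylbenzyl or 4-chlorobenzyl amides remains open, as does the outcome with a longer chain such as 2-phenylethyl on the amide-type nitrogen, or with an amine or a carboxylic acid on its aromatic ring.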